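The source may hold more compounds than are shown below. What is called first, only, known or untested is meant among the compounds shown, and "the series" means these compounds.

The series is followed in a functional assay on HL-60 cells (Homo sapiens) for activation, read by flow cytometry, with a stated time of 4 days; on this read-out higher numbers stand for an effect only at larger amounts of compound and lower numbers for an effect already at smaller amounts. Compound 1 `Cc1cc(F)ccc1-c1cc2c(cn1)ncn2-c1ccc(S(C)(=O)=O)cc1` gives only a limit, > 30000 nM, in this assay. Among the compounds with values here, compound 2 `COc1cc(F)ccc1-c1cc2c(cn1)ncn2-c1ccc(OC(F)F)cc1` gives 93 nM in this assay, the sole number among the two values shown. The other value shown sits at the limit of > 30000 nM in this assay, at which 1 of the 2 values shown sits. Compound 3 `CCCOc1cc(F)ccc1-c1cc2c(cn1)ncn2-c1ccc(OC(F)F)cc1` carries ethyl in place of hydrogen on a saturated chain carbon bound to an oxygen on an aromatic ring and is not yet measured in this assay. The step from compound 2 to compound 3 is expected to be small, at or near the scatter, leaning if anything toward weaker, a 1.6-fold higher number from compound 2 to compound 3 (0.21 log units; within the scatter). For compound 3 the estimate in this assay is 150 nM, with a range from 40 nM to 600 nM.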

Compound 3, half-maximal effective concentration: 58 nM
Compound 3: the middle estimate sits 2.6-fold (0.41 log units) above what was measured, within the range that was stated.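

In this assay, going from methoxy to propoxy gives a 1.6-fold lower number from compound 2 to compound 3 (0.21 log units; within the scatter), so the added ethyl on a saturated chain carbon bound to an oxygen on an aromatic ring is tolerated, with no difference beyond the scatter. This rests on a single pair of compounds, and nothing given here bears on a cause for this step. Going by these compounds, whether a longer chain, a branched chain or a terminal amine at this place would keep the read-out in the same range remains open.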